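Crown ether esters: pyridin-3-yl to 4-cyclohexylbutyl on the carbonyl

This account rests on a few compounds, and the source may have more. Where it says the series, first, only, none or still open, it means among the compounds named here.

Compound 3 `O=C(OCC1COCCOCCOCCOCCOCCO1)c1cccnc1` carries a pyridin-3-yl group on the carbonyl carbon of the shared core. In a functional assay on WiDr cells (Homo sapiens) for inhibition, read by sulforhodamine B assay, with a stated time of 48 h (on this read-out lower numbers stand for stronger inhibition of growth and higher numbers for weaker inhibition of growth), compound 3 gives > 100000 nM, which is a limit of the assay and not a number. Compound 1 `O=C(CCCCCc1ccccc1)OCC1COCCOCCOCCOCCOCCO1` bears a 5-phenylpentyl chain in the same place; in this assay compound 1 gives > 100000 nM, again a limit. Compound 2 `CC(=O)OCC1COCCOCCOCCOCCOCCO1` is the acetate; in this assay compound 2 gives > 100000 nM, also a limit. All three values sit at the limit of > 100000 nM in this assay, at which 3 of the 3 values shown sit, so every step among them is unreadable: a step that the two limits leave unreadable from compound 1 to compound 2, a step that the two limits leave unreadable from compound 1 to compound 3 and a step that the two limits leave unreadable from compound 2 to compound 3.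

Compound 4 `O=C(CCCCC1CCCCC1)OCC1COCCOCCOCCOCCOCCO1` arises from compound 3 by the change (4-cyclohexylbutyl in place of pyridin-3-yl on a carbonyl carbon). Among the compounds with values here, the steps that bear on it are those from the acyl chains to the pyridin-3-yl ester, and none of them yields a readable size. Compound 1, whose 5-phenylpentyl chain is closest in kind to the 4-cyclohexylbutyl chain of compound 4, sits at the same limit as compound 3. Within the data shown here, no measured step points to a change beyond the scatter, and a fourth limit is the most likely outcome. Compound 4 is therefore expected to give about 150000 nM in this assay, with a range from 50000 nM to 500000 nM. The expected step that the limit leaves unreadable from compound 3 to compound 4 is estimated as none beyond the scatter.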

Compound 4, concentration for 50% growth inhibition: 33000 nM
Compound 4: the middle estimate sits 4.5-fold (0.66 log units) above what was measured; the whole stated range lies above it.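

On the carbonyl carbon of the shared core, 4-cyclohexylbutyl is the first group shown to give a numerical value rather than a limit in this assay, with an at least 3.0-fold lower number from compound 3 to compound 4 (0.48 log units; beyond the scatter). The acetate ester and the chain ending in phenyl are also left behind, with an at least 3.0-fold lower number from compound 2 to compound 4 (0.48 log units; beyond the scatter) and an at least 3.0-fold lower number from compound 1 to compound 4 (0.48 log units; beyond the scatter), and the second of these steps shows that a long acyl chain ending in a ring is not sufficient in itself, since the cyclohexyl end and the phenyl end give different results here. Each step gives only a minimum size, because the other three compounds all rest on the same limit: the limit of > 100000 nM in this assay, at which 3 of the 4 values shown sit.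

As far as these compounds go, the steps among compound 1, compound 2 and compound 3 cannot be read, and the full size of each step to compound 4 remains unknown. Still open, from the compounds shown here alone, is whether the ring itself is needed, which an unbranched alkyl chain of similar length would test, and whether a shorter or longer chain to the cyclohexyl ring, or an amine or carboxylic acid on that ring, would keep the inhibition of growth.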